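From Nitrile to Amine on the Distal Ring

The compounds below may be only part of what the source reports. "The series", "measured", "known", "first", "only" and "open" are said of these compounds alone.

Compound 1 `Cc1cccc(C#Cc2ccc(CCC(=O)O)cc2)c1` and compound 2 `N#Cc1cccc(C#Cc2ccc(CCC(=O)O)cc2)c1` share one core and differ in a single aromatic substituent. In an in vitro functional assay on 1321-N1 cells for agonist activity at Free fatty acid receptor 1 (Homo sapiens), read by fluorescence (on this read-out higher numbers stand for an effect only at larger amounts of compound and lower numbers for an effect already at smaller amounts), compound 1 gives 43.7 nM, and compound 2 gives 91.2 nM. Going by the values given here, the one measured step, a 2.1-fold higher number from compound 1 to compound 2 (0.32 log units; beyond the scatter), is a modest loss. Among the compounds with values here, compound 2 therefore stands at the higher of the two numbers, with compound 1 as its only neighbour a modest step lower. Compound 3 `Nc1cccc(C#Cc2ccc(CCC(=O)O)cc2)c1` has not yet been measured; it differs from compound 2 as follows: amino in place of cyano on an aromatic carbon. Within the data shown here, no measured step matches this exchange; the only known step swapped methyl for cyano and stayed modest, so the two substituents tried at this position gave numbers not far apart. The change to compound 3 is expected to amount to a 1.3-fold lower number from compound 2 to compound 3 (0.11 log units; within the scatter), within the scatter. Compound 3 is estimated at 70 nM, in a range from 25 nM to 250 nM.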

Compound 3, half-maximal effective concentration: 1100 nM
For compound 3 the middle estimate is 16-fold (1.20 log units) below the measured one; measured number above the stated range.
By their numbers in this assay, from the lowest: compound 1; then compound 2; then compound 3.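

The exchange shows that this position on the distal ring is far from indifferent to its substituent: amino in place of cyano gives a 12-fold higher number from compound 2 to compound 3 (1.08 log units; beyond the scatter), a large step where methyl to cyano had been only modest. Amino also stands clearly apart from methyl, with a 25-fold higher number from compound 1 to compound 3 (1.40 log units; beyond the scatter), so among the three groups tried here, the amino compound alone breaks from the narrow spread of the other two. The exchange brings in a hydrogen-bond donor that neither cyano nor methyl carries, but no measurement available here accounts for the large step.

The compounds shown leave open whether a hydroxyl or methoxy group here would behave like amino or like methyl and cyano. They also leave open whether a dimethylamino group or an acetamide would recover the lost ground.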